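Thiophen-2-yl for methyl on the shared core

The source may report more compounds than this note shows. Statements on the series, on what has been measured and on what is new or still open speak of the compounds shown alone.

Three compounds of the series have numbers in an assay on isolated protein for inhibition of ribosomal protein S6 kinase alpha-5 (Homo sapiens), read by mobility shift assay, tested at 30 uM; on this read-out lower numbers stand for less inhibition and higher numbers for more inhibition at the one concentration tested (going by the name of the read-out). Compound 1 `Cc1cc2[nH]nc(N)c2c(=O)[nH]1` gives 56% in this assay, the highest of the three. Compound 3 `COc1cccc(-c2cc3[nH]nc(N)c3c(=O)[nH]2)c1` carries a methoxyphenyl group where compound 1 carries methyl; in this assay compound 3 gives 49%. This lies within the scatter of compound 1, so no order between them can be read. Compound 2 `Nc1n[nH]c2cc(-c3ccncc3)[nH]c(=O)c12`, with pyridinyl in that position, gives 29%, which lies beyond the scatter below compound 1. Among the measured compounds shown here, both ring groups at this position thus sit at or under the methyl compound, and no step between measured compounds is available.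

Compound 4 `Nc1n[nH]c2cc(-c3cccs3)[nH]c(=O)c12` is not yet measured. It differs from compound 1 as follows: thiophen-2-yl in place of methyl on an aromatic carbon.

The change again puts an aromatic ring in place of methyl. On the showing of compound 3 with 49% and compound 2 with 29%, a moderate drop is expected; the step of a number 14 percentage points lower from compound 1 to compound 4 (beyond the scatter) is estimated to reach just beyond the scatter. Compound 4 is expected to give about 42%, with a range from 25% to 60%.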

Compound 4, a percentage reported as inhibition, at one concentration (the size of the read-out at that concentration, not a potency): 63%
Estimate against measurement, compound 4: 21 percentage points below; the measured number lies above the stated range.
By their numbers in this assay, from the lowest: compound 2; then compounds 3, 1 and 4 (each within the scatter of the next, the first and the last beyond it).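

In this assay, thiophen-2-yl in place of methyl on this aromatic carbon gives a number 7 percentage points higher from compound 1 to compound 4 (within the scatter), so this position accepts an aromatic ring here with no loss that can be read. A ring at this position therefore does not by itself bring the number beyond the scatter below the methyl compound; among the ring groups, the pyridinyl of compound 2 at 29% goes against any such rule, while thiophen-2-yl does not follow it. Nothing measured here explains why these ring groups part ways.

Open, as far as these compounds go, is whether a saturated ring such as cyclohexyl, an aminomethyl group, a carboxylic acid or a longer alkyl chain at this carbon would stay with compound 1 or fall toward compound 2. Readings at one concentration also leave potency for this series undefined.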